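The compounds below may be only part of what the source reports. "The series", "measured", "known", "first", "only" and "open" are said of these compounds alone.

Measured compounds in an assay on isolated protein for binding affinity to B1 bradykinin receptor (Homo sapiens); a lower number here means a stronger inhibitor, a higher number a weaker inhibitor:
- compound 1 `Cc1cc(C)c2cccc(OCc3c(Cl)ccc(S(=O)(=O)NC4(C(=O)N5CCN(C(=O)[C@@H](N)CCCCN)CC5)CCCC4)c3Cl)c2n1`: < 10000 nM
- compound 2 `Cc1cc(C)c2cccc(OCc3c(Cl)ccc(S(=O)(=O)NC4(C(=O)N5CCN(C(=O)CCCC[N+](C)(C)C)CC5)CCCC4)c3Cl)c2n1`: < 10000 nM

Compound 1 gives only a limit of the assay, < 10000 nM, in this assay. Compound 2 likewise gives only a limit, < 10000 nM, in this assay. Both measured values therefore sit at the limit of < 10000 nM in this assay, at which 2 of the 2 values shown sit, and compound 2 stands nowhere better defined than at that limit. Among the compounds with values here, the one measured step, a step that the two limits leave unreadable from compound 1 to compound 2, cannot be read in size or direction since both ends are limits.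

Compound 3 `Cc1cc(C)c2cccc(OCc3c(Cl)ccc(S(=O)(=O)NC4(C(=O)N5CCN(C(=O)[C@@H](N)CCC[N+](C)(C)C)CC5)CCCC4)c3Cl)c2n1` is not yet measured in this assay. Its change from compound 2 is amino in place of hydrogen on a saturated chain carbon bound to a carbonyl carbon and a saturated chain carbon. Within the data shown here, no measured step addresses the addition of an amino group at that position; the step from compound 1 to compound 2 touches the same acyl group but gives no readable size. Nothing in the two measured values shows a direction for this change, so no step beyond the scatter is expected: a step that the limit leaves unreadable from compound 2 to compound 3 is the expected step.

Compound 3 is estimated at 1000 nM, within a range of 30 nM to 10000 nM, with a substantial chance that this assay again reports only a limit.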

Compound 3, inhibition constant: < 10000 nM
Compound 3: a limit, no number; the forecaster's own chance of this, stated with the estimate: 75%; the middle value does not contradict the limit.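

In this assay compound 3 gives < 10000 nM, a limit and not a number. No step among compound 1, compound 2 and compound 3 can be read in size or direction, as all three values rest on one limit: the limit of < 10000 nM in this assay, at which 3 of the 3 values shown sit.

The compounds shown leave open how the three compare in affinity, and whether amino in place of hydrogen changes it at all.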